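The source may report more compounds than this note shows. Statements on the series, on what has been measured and on what is new or still open speak of the compounds shown alone.

Measured compounds:
compound 1 `COc1cc(C)cc(-c2c(-c3ccnc(-c4ccc(C(C)=O)cc4)c3)cnn2CC#N)c1` with -27%
compound 2 `COc1cc(C)cc(-c2nn(CC#N)cc2-c2ccc(-c3cccc(C(C)=O)c3)nc2)c1` with 1%
compound 3 `COc1cc(C)cc(-c2nn(CC#N)cc2-c2ccnc(-c3ccc(N(C)C)cc3)c2)c1` with -41%

All three were tested in a functional assay on HCT-116 cells (Homo sapiens) for cytotoxicity, read by sulforhodamine B assay, with a stated time of 48 h, tested at 1 uM; on this read-out lower numbers stand for a stronger effect and higher numbers for a weaker effect at the one concentration tested. Compound 1 stands second highest of the three numbers. Its nearest neighbour is compound 3, whose number lies lower by a gap beyond the usual scatter, and the furthest is compound 2, whose number lies higher, again beyond the scatter. None of these three pairs differs in only one place, so the numbers can only be read side by side, not as single steps.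

The unmeasured compound 4 `COc1cc(C)cc(-c2c(-c3ccnc(-c4ccc(N(C)C)cc4)c3)cnn2CC#N)c1` is the direct one-place neighbour of compound 1. The change is dimethylamino in place of acetyl on an aromatic carbon. Compound 3 also carries dimethylamino on its phenyl and gives -41% in this assay, but compound 3 differs from compound 1 in more than that one place, so it can only hint at the direction.

For compound 4 a step in the lower direction, that is towards a stronger effect, is expected, of size a number 8 percentage points lower from compound 1 to compound 4 (within the scatter), small enough that it may not clear the scatter. Compound 4 is therefore estimated at -35% in this assay, within a range from -58% to -10%.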

Compound 4, a percentage reported as activity, at one concentration (the size of the read-out at that concentration, not a potency): -33%
Compound 4: the middle estimate sits 2 percentage points below what was measured; the range from low to high includes it.
By their numbers in this assay, from the lowest: compounds 3, 4 and 1 (each within the scatter of the next, the first and the last beyond it); then compound 2.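

Putting dimethylamino in place of acetyl on an aromatic carbon, para to a large group, gives in this assay a number 6 percentage points lower from compound 1 to compound 4 (within the scatter), so this one change does not separate the two compounds at the single concentration tested. Going by these compounds alone, this is the first reading of a single change in the set, since the earlier compounds could only be set side by side, and it shows that at this position the 4-acetylphenyl can become a 4-(dimethylamino)phenyl with no change in the read-out that stands clear of the usual scatter. No supporting measurement is available that would explain this outcome, so the pair records what happens and not why.

Going by these compounds, whether a group of another kind at the same position, such as a carboxylic acid or a primary amine, would also leave the read-out within the scatter remains open. Also open, on these data alone, is whether compound 1 and compound 4 would still match at other concentrations, since a reading at one concentration is not a potency.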